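Changing the Sulfonyl Aryl of Compound 2

The compounds below may be only part of what the source reports. "The series", "measured", "known", "first", "only" and "open" are said of these compounds alone.

In an ADME assay on microsomes from liver (Homo sapiens) for metabolic stability, tested at 2.5 uM (on this read-out higher numbers stand for fast clearance and lower numbers for slow clearance), compound 2 `O=S(=O)(c1ccc(F)c(Cl)c1)c1cnc2c(F)cccc2c1-c1ccc(Cl)cc1` gives 0.01 mL/min, the lowest of the three numbers recorded. Compound 1 `O=S(=O)(c1cccc(F)c1)c1cnc2c(F)cccc2c1-c1cccc(Cl)c1` gives 0.56 mL/min and compound 3 `O=S(=O)(c1ccc(F)c(Cl)c1)c1cnc2c(F)cccc2c1-c1cccc(F)c1` gives 1.23 mL/min; both steps from compound 2 lie beyond the scatter, so compound 2 is cleared most slowly of the three.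

Compound 4 `O=S(=O)(c1cccc(F)c1)c1cnc2c(F)cccc2c1-c1ccc(Cl)cc1` is not yet measured. It differs from compound 2 in one place: 3-fluorophenyl in place of 3-chloro-4-fluorophenyl on a sulfonyl sulfur.

Among the compounds with values here, only one measured step exists, and it does not touch the sulfonyl side: a 120-fold higher number from compound 2 to compound 3 (2.09 log units; beyond the scatter). It shows that a single change elsewhere in this series can move this assay a long way. Within the data shown here, no pair of measured compounds differs solely at the sulfonyl aryl, so the size and direction of the present change have no direct precedent. Compound 1 carries the same 3-fluorophenyl on sulfonyl sulfur as compound 4 and shows a higher number than compound 2, but compound 1 and compound 4 also differ in the other aryl, so their values only loosely bound the outcome.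

Weighing these, compound 4 is estimated at 0.08 mL/min, with a range from 0.02 mL/min to 0.4 mL/min, an expected step of an 8.0-fold higher number from compound 2 to compound 4 (0.90 log units; beyond the scatter) that is likely upward.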

Compound 4, intrinsic clearance in a liver preparation (reported as CLH), per the amount of preparation that the assay uses: 0.62 mL/min
The estimate for compound 4 lay 7.8-fold (0.89 log units) below the measured number; measured number above the stated range.
By their numbers in this assay, from the lowest: compound 2; then compounds 1, 4 and 3 (each within the scatter of the next, the first and the last beyond it).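

The exchange on the sulfonyl sulfur now has a measured size: in this assay the step is a 62-fold higher number from compound 2 to compound 4 (1.79 log units; beyond the scatter) and so lies beyond the scatter, with 3-fluorophenyl in place of 3-chloro-4-fluorophenyl. With 3-fluorophenyl held on the sulfonyl sulfur, the change on the aromatic carbon gives a 1.1-fold higher number from compound 1 to compound 4 (0.04 log units; within the scatter) and stays within the scatter, so 4-chlorophenyl and 3-chlorophenyl cannot be told apart in this setting. Among these compounds, the low number belongs only to compound 2, the one compound that pairs 3-chloro-4-fluorophenyl on the sulfonyl sulfur with 4-chlorophenyl on the aromatic carbon, and nothing given here accounts for the size of the step.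

The compounds shown leave open whether that low number depends on the chlorine or the fluorine of the 3-chloro-4-fluorophenyl, as a 3-chlorophenyl or a 4-fluorophenyl on the sulfonyl sulfur would show. They also leave open whether a group of another kind at this place, such as a cyclopropyl or a morpholine, would stay close to compound 2 or to compound 4 in this read-out.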